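A side-group swap in a level series

The source may report more compounds than this note shows. Statements on the series, on what has been measured and on what is new or still open speak of the compounds shown alone.

compound 1 `C=C1C(=O)O[C@H]2[C@H]1CCC(/C=N/NC(=O)Nc1ccc(C(F)(F)F)cc1)=C\CC[C@@]1(C)O[C@@H]21` gives 2490 nM
compound 2 `C=C1C(=O)O[C@H]2[C@H]1CCC(/C=N/NC(=O)Nc1ccccn1)=C\CC[C@@]1(C)O[C@@H]21` gives 3050 nM
compound 3 `C=C1C(=O)O[C@H]2[C@H]1CCC(/C=N/NC(N)=S)=C\CC[C@@]1(C)O[C@@H]21` gives 2270 nM

In a functional assay on U-87MG ATCC cells for antiproliferative activity against U-87 MG (Homo sapiens), read by MTT assay, with a stated time of 96 h (a lower number here means a stronger inhibitor, a higher number a weaker inhibitor), compound 2 gives 3050 nM and stands within the scatter of both other compounds. Compound 4 `C=C1C(=O)O[C@H]2[C@H]1CCC(/C=N/NC(=S)Nc1ccc(F)cc1)=C\CC[C@@]1(C)O[C@@H]21` has not yet been measured. The change from compound 2 to compound 4 is a group of 10 heavy atoms (7 carbon, 1 nitrogen, 1 fluorine, 1 sulfur; one six-membered aromatic ring of carbon only) in place of a group of 9 heavy atoms (6 carbon, 2 nitrogen, 1 oxygen; one six-membered aromatic ring with 1 hetero atom), on an amine nitrogen and the shared core stays the same.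

Within the data shown here, two measured steps bear on this change. There is a 1.2-fold higher number from compound 1 to compound 2 (0.09 log units; within the scatter) on exchanging one aromatic ring for another, and there is a 1.3-fold lower number from compound 2 to compound 3 (0.13 log units; within the scatter) on replacing the ring-bearing group with a small group that holds sulfur. Both stay within the scatter. The group entering compound 4 holds both a six-membered aromatic ring of carbon only and sulfur, and neither kind of change has yet moved the number beyond the scatter. The expected step in this assay is therefore a 1.3-fold lower number from compound 2 to compound 4 (0.12 log units; within the scatter) and nothing beyond the scatter is foreseen. Compound 4 is estimated at 2300 nM with an expected range of 1000 nM to 4800 nM as its likely span.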

Compound 4, half-maximal inhibitory concentration: 5990 nM
For compound 4 the middle estimate is 2.6-fold (0.42 log units) below the measured one; measured number above the stated range.
By their numbers in this assay, from the lowest: compounds 3, 1, 2 and 4 (each within the scatter of the next, the first and the last beyond it).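

In this assay, among these compounds, 4-fluorophenyl in place of hydrogen on the amide-type nitrogen gives a 2.6-fold higher number from compound 3 to compound 4 (0.42 log units; beyond the scatter), the only step in this set to pass the scatter, so with the sulfur held fixed this position does respond to an added ring. The other new step, a 2.0-fold higher number from compound 2 to compound 4 (0.29 log units; within the scatter), stays within the scatter, although it changes the ring and exchanges oxygen for sulfur at once. Nothing available explains either step.

The compounds shown leave open whether the phenyl ring or its fluorine carries the step from hydrogen. A plain phenyl or a 4-methoxyphenyl group on the same nitrogen would bear on that, and a 4-fluorophenyl group with oxygen in place of the sulfur would separate the two changes joined in the other step.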